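Compound 3 to compound 4: a change on the aryl ring

The source may report more compounds than this note shows. Statements on the series, on what has been measured and on what is new or still open speak of the compounds shown alone.

Compound 1, `CCC1(CCCCN2CCN(c3cccc(Cl)c3)CC2)C(=O)Nc2ccccc21`, gives 0.41 nM in an assay on CHO cells for displacement of a labelled ligand from 5-hydroxytryptamine receptor 7 (Homo sapiens); a higher number here means a weaker inhibitor, a lower number a stronger inhibitor.
Compound 2, `CCC1(CCCCN2CCN(c3ccccc3OC)CC2)C(=O)Nc2ccccc21`, gives 5.38 nM in this assay.
Compound 3, `CCC1(CCCCN2CCN(c3ccccc3Cl)CC2)C(=O)Nc2ccccc21`, gives 5.11 nM in this assay.

Compound 3 holds the second highest of the three numbers: the step of a 1.1-fold lower number from compound 2 to compound 3 (0.02 log units; within the scatter) is within the scatter, while the step of a 12-fold higher number from compound 1 to compound 3 (1.10 log units; beyond the scatter) is large. Compound 4, `CCC1(CCCCN2CCN(c3ccc(C)c(Cl)c3)CC2)C(=O)Nc2ccccc21`, differs from compound 3 by 3-chloro-4-methylphenyl in place of 2-chlorophenyl on an amine nitrogen in a ring. For the measured compounds named here, the step of a 12-fold higher number from compound 1 to compound 3 (1.10 log units; beyond the scatter) bears directly on this change, since it also exchanges a 2-chlorophenyl against a 3-chlorophenyl, only in the reverse direction; the added methyl has no counterpart among the measured compounds. A large step to a lower number in this assay is therefore expected, a 6.4-fold lower number from compound 3 to compound 4 (0.81 log units; beyond the scatter). For compound 4 the estimated value in this assay is 0.8 nM, with a range from 0.2 nM to 4 nM.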

Compound 4, inhibition constant: 0.66 nM
Compound 4: the middle estimate sits 1.2-fold (0.08 log units) above what was measured; the range from low to high includes it.
By their numbers in this assay, from the lowest: compounds 1 and 4 (each within the scatter of the next); then compounds 3 and 2 (each within the scatter of the next).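

In this assay, methyl in place of hydrogen on an aromatic carbon gives a 1.6-fold higher number from compound 1 to compound 4 (0.21 log units; within the scatter) and so stays within the scatter, which shows that this carbon of the 3-chlorophenyl group takes a methyl without a measurable change. The steps of a 7.7-fold lower number from compound 3 to compound 4 (0.89 log units; beyond the scatter) and an 8.2-fold lower number from compound 2 to compound 4 (0.91 log units; beyond the scatter) lie beyond the scatter, so 3-chloro-4-methylphenyl keeps the advantage of compound 1 over the 2-chlorophenyl and 2-methoxyphenyl compounds. Nothing available here explains these steps.

From the compounds shown here alone, it remains open whether an ethyl, a trifluoromethyl or an amine at the methyl-bearing carbon would fare the same. Going by these compounds, it is also open whether that methyl would be accepted without the chloro.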